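Swapping an acyl for an aryl on a piperazine

This account rests on a few compounds, and the source may have more. Where it says the series, first, only, none or still open, it means among the compounds named here.

Compound 2, `COC(=O)CC/C(C)=C/Cc1c(OC)c(C)c2c(c1OCC#CCN1CCN(C(=O)C3COc4ccccc4O3)CC1)C(=O)OC2`, is the starting point of this step. In a functional assay on FaDu cells (Homo sapiens) for inhibition, read by sulforhodamine B assay (a higher number here means a weaker inhibitor, a lower number a stronger inhibitor), compound 2 gives only a limit, > 50000 nM, and no number. Compound 1, `COC(=O)CC/C(C)=C/Cc1c(OC)c(C)c2c(c1OCC#CCN1CCCc3ccccc31)C(=O)OC2`, shares the same core with a different amine; in this assay compound 1 likewise reaches only a limit, > 50000 nM. Among the compounds with values here, compound 3, `CCCCNc1ccc(CC#CCOc2c(C/C=C(\C)CCC(=O)OC)c(OC)c(C)c3c2C(=O)OC3)cc1`, is the one compound of the three with a measured number, 21200 nM in this assay. Within the data shown here, the single step between two measured compounds that differ in one place, an at least 2.3-fold lower number from compound 1 to compound 3 (0.37 log units; beyond the scatter), concerns the amine end of the chain and not the piperazine nitrogen. Compound 4, `COC(=O)CC/C(C)=C/Cc1c(OC)c(C)c2c(c1OCC#CCN1CCN(c3ccccc3OC)CC1)C(=O)OC2`, has not yet been measured. It differs from compound 2 as follows: 2-methoxyphenyl in place of (2,3-dihydro-1,4-benzodioxin-2-yl)carbonyl on an amine nitrogen in a ring. Among the measured compounds shown here, no measured step bears on this change, as none of the three compounds varies the group on the piperazine nitrogen. With two of the three values sitting at the limit, as recorded in the limit of > 50000 nM in this assay, at which 2 of the 3 values shown sit, the expectation for compound 4 in this assay is a step of about an at least 1.1-fold lower number from compound 2 to compound 4 (0.04 log units; that floor lies within the scatter), that is, no change beyond the scatter. Compound 4 is therefore estimated to give 45000 nM, within a range from 15000 nM to 150000 nM, with a fair chance that only a limit is returned.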

Compound 4, half-maximal inhibitory concentration: > 50000 nM
Compound 4 ended at the assay's limit; the forecaster's own chance of this, stated with the estimate: 60%; middle value at least 1.1-fold (0.04 log units) away from the limit.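

Compound 2 and compound 4 both return only a limit in this assay, so no step can be read for 2-methoxyphenyl in place of (2,3-dihydro-1,4-benzodioxin-2-yl)carbonyl: the limit of > 50000 nM in this assay, at which 3 of the 4 values shown sit.

The compounds shown leave open whether these two groups differ at all in this assay, and whether any group on that piperazine nitrogen gives a measurable value.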